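Aryl for pyrazolyl on the ring nitrogen: cytotoxicity outlook

A few compounds are considered here, and "the series" means these few. Any claim that something is new, unique, unknown or untested is made for them only; others in the source may bear on it.

Compound 1 `CS(=O)(=O)CCCn1c(Cn2c(=O)n(C3CN(S(C)(=O)=O)C3)c3ccncc32)cc2cc(Cl)ccc21` was tested in an ADME assay on HeLa cells (Homo sapiens) for cytotoxicity, read by ATP content, with a stated time of 3 days (a higher number here means that more compound is tolerated, a lower number that less compound is tolerated), and gave only the limit > 50000 nM, not a number.
Compound 2 `Cn1ccc(-n2c(=O)n(Cc3cc4cc(Cl)ccc4n3CCCC#N)c3cnccc32)n1` gave in this assay only the limit > 50000 nM, not a number.

Compound 2 thus stands where the other measured compound stands: the limit of > 50000 nM in this assay, at which 2 of the 2 values shown sit. For the measured compounds named here, because both values are limits, they show only that neither compound 1 nor compound 2 was tolerated less than the limit, and no step between them can be sized. Compound 3 `COc1ccc(-n2c(=O)n(Cc3cc4cc(Cl)ccc4n3CCCC#N)c3cnccc32)c(F)c1` has not yet been measured in this assay. It differs from compound 2 in one place: 2-fluoro-4-methoxyphenyl in place of 1-methyl-1H-pyrazol-3-yl on an aromatic nitrogen. Going by the values given here, no measured step shows how this change bears on this assay, so the expectation rests on the two limits alone. The step of a number no higher from compound 2 to compound 3 (the limit leaves the size open) is expected to be none beyond the usual scatter. Compound 3 is estimated at 50000 nM, in a range from 20000 nM to 100000 nM, and is expected most likely to be reported again as a limit.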

Compound 3, half-maximal cytotoxic concentration: > 50000 nM
Compound 3: a limit, no number; the forecaster's own chance of this, stated with the estimate: 75%; the middle value lies on the limit itself.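

The step from compound 2 to compound 3 cannot be read in this assay, and all three compounds share one limit: the limit of > 50000 nM in this assay, at which 3 of the 3 values shown sit.

The compounds shown leave open what half-maximal cytotoxic concentration any of them has in this assay, and whether 2-fluoro-4-methoxyphenyl and 1-methyl-1H-pyrazol-3-yl differ there at all.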